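A few compounds are considered here, and "the series" means these few. Any claim that something is new, unique, unknown or untested is made for them only; others in the source may bear on it.

Measured so far:
Compound 1, `COc1cc(OC)c(C(=O)/C=C/c2ccccc2Cl)c(O)c1CN(C)CCCN(C)C`; in a functional assay on PC-3 cells (Homo sapiens) for antiproliferative activity, with a stated time of 72 h (on this read-out higher numbers stand for weaker inhibition and lower numbers for stronger inhibition), compound 1 gives 14500 nM.
Compound 2, `COC(=O)CN(C)Cc1c(OC)cc(OC)c(C(=O)/C=C/c2ccccc2Cl)c1O`; in this assay compound 2 gives 7200 nM.

Going by the values given here, compound 2 holds the lower of the two numbers, and its only neighbour is compound 1, the pair separated by a 2.0-fold lower number from compound 1 to compound 2 (0.30 log units; within the scatter); the two values therefore sit within the scatter of each other, and neither can be called the stronger inhibitor.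

Compound 3, `COc1cc(OC)c(C(=O)/C=C/c2ccccc2Cl)c(O)c1CN(C)CC(=O)O`, differs from compound 2 by hydrogen in place of methyl on an oxygen next to a carbonyl group. Among the compounds with values here, the one measured step that bears on this region is the change from compound 1 to compound 2, which also reworked the substituent on the saturated chain carbon bound to the amine nitrogen, and it stayed within the scatter. Within the data shown here, no measured pair shows methoxycarbonyl set against carboxy. With a single step of that size as guide, the expectation for this assay is no shift beyond the scatter in either direction, with a wide margin of uncertainty.

Compound 3 is thus expected to give 8000 nM, estimated to lie between 3000 nM and 25000 nM, which corresponds to an expected step of a 1.1-fold higher number from compound 2 to compound 3 (0.05 log units; within the scatter).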

Compound 3, half-maximal inhibitory concentration: 12500 nM
Beside the measured number, compound 3's estimate is 1.6-fold (0.19 log units) below it; the range from low to high includes it.
By their numbers in this assay, from the lowest: compounds 2, 3 and 1 (each within the scatter of the next).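

Going by these compounds alone, replacing methyl with hydrogen on the oxygen next to a carbonyl group turns methoxycarbonyl into carboxy, and in this assay this change gives a 1.7-fold higher number from compound 2 to compound 3 (0.24 log units; within the scatter), which provides the first direct comparison of these two groups. Setting carboxy in place of 2-(dimethylamino)ethyl on the saturated chain carbon bound to an amine nitrogen gives a 1.2-fold lower number from compound 1 to compound 3 (0.06 log units; within the scatter), so compound 1, compound 2 and compound 3 all lie within the scatter of one another, and none of the three groups at this place can be ranked above another in this assay. No evidence is available that bears on this result.

The compounds shown leave open whether a carboxamide, or a longer chain ending in a carboxylic acid, would also stay within the scatter of these three compounds on the shared core. They also leave open whether a cyclic amine in place of the methyl-substituted amine nitrogen would give a step beyond the scatter in this assay.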